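The compounds below may be only part of what the source reports. "The series", "measured", "known", "first", "only" and "open" are said of these compounds alone.

Measured compounds:
compound 1, `O=C(Nc1ccc(Oc2ccnc3[nH]ccc23)cc1)c1cc2cccnc2n(-c2ccc(F)c(Cl)c2)c1=O`, 560 nM in a functional assay on HT-29 cells (Homo sapiens) for antiproliferative activity, read by MTT assay, with a stated time of 72 h; on this read-out lower numbers stand for stronger inhibition and higher numbers for weaker inhibition
compound 2, `COc1ccc(-n2c(=O)c(C(=O)Nc3ccc(Oc4ccnc5[nH]ccc45)c(F)c3)cc3cccnc32)cc1`, 540 nM

In this assay compound 2 and compound 1 sit within the usual scatter of each other, so neither stands apart on these numbers. Compound 3, `O=C(Nc1ccc(Oc2ccnc3[nH]ccc23)c(F)c1)c1cc2cccnc2n(-c2ccc(F)c(Cl)c2)c1=O`, is not yet measured. It differs from compound 2 by 3-chloro-4-fluorophenyl in place of 4-methoxyphenyl on an aromatic nitrogen, the same group that compound 1 carries. Since compound 1 and compound 2 give numbers that do not differ beyond the scatter, no step beyond the scatter is expected from compound 2 to compound 3 in this assay. Compound 3 is therefore estimated at 520 nM, with a range from 200 nM to 1400 nM, which is an expected step of a 1.0-fold lower number from compound 2 to compound 3 (0.02 log units; within the scatter).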

Compound 3, half-maximal inhibitory concentration: 310 nM
Estimate against measurement, compound 3: 1.7-fold (0.22 log units) above; low and high end bracket the measured number.
By their numbers in this assay, from the lowest: compounds 3, 2 and 1 (each within the scatter of the next).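

In this assay, 3-chloro-4-fluorophenyl in place of 4-methoxyphenyl on the aromatic nitrogen gives a 1.7-fold lower number from compound 2 to compound 3 (0.24 log units; within the scatter) and fluoro in place of hydrogen on an aromatic carbon gives a 1.8-fold lower number from compound 1 to compound 3 (0.26 log units; within the scatter) for the second change. Neither single change therefore takes the number beyond the scatter, so these two aromatic groups on that nitrogen cannot be told apart here. No measured evidence bears on these small steps.

Going by these compounds, whether a longer chain ending in an amine on that nitrogen would give a step beyond the scatter stays open. So does whether the fluoro step would look the same with 4-methoxyphenyl on the nitrogen.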